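This account rests on a few compounds, and the source may have more. Where it says the series, first, only, none or still open, it means among the compounds named here.

Three compounds that share one core have been examined in an ADME assay on J774 cells (Mus musculus) for cytotoxicity, read by MTT assay, with a stated time of 48 h, tested at 150 ug/mL; on this read-out higher numbers stand for a weaker effect at the one concentration tested and lower numbers for a stronger effect. Compound 1 `O=C(N/N=C/c1ccc(F)cc1)c1cnccn1` gives 71%. Compound 2 `COc1ccc(/C=N/NC(=O)c2cnccn2)cc1` gives 55%. Compound 3 `O=C(N/N=C/c1ccc(O)cc1)c1cnccn1` gives 80%. On these numbers compound 3 carries the highest value, with compound 1 within the scatter of it and compound 2 beyond it. The move a number 16 percentage points lower from compound 1 to compound 2 (beyond the scatter) and the move a number 25 percentage points higher from compound 2 to compound 3 (beyond the scatter) both lie beyond the scatter, whereas a number 9 percentage points higher from compound 1 to compound 3 (within the scatter) stays within it.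

Compound 4 `N#Cc1ccc(/C=N/NC(=O)c2cnccn2)cc1` has not yet been measured. It differs from compound 3 in one place: cyano in place of hydroxy on an aromatic carbon. Within the data shown here, no measured step places a cyano group on an aromatic carbon of this core; the steps at hand exchange fluoro, methoxy and hydroxy there. a number 9 percentage points higher from compound 1 to compound 3 (within the scatter) shows that one such exchange left the read-out unmoved, while a number 25 percentage points higher from compound 2 to compound 3 (beyond the scatter) shows that another moved it modestly. All measured values lie between those of compound 2 and compound 3, so a modest step in either direction, or none beyond the scatter, is the most the data support. Compound 4 is therefore expected to give 68%, between 50% and 85%. The step expected from this estimate is a number 12 percentage points lower from compound 3 to compound 4 (beyond the scatter).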

Compound 4, a percentage reported as activity, at one concentration (the size of the read-out at that concentration, not a potency): 100%
For compound 4 the middle estimate is 32 percentage points below the measured one; measured number above the stated range.
By their numbers in this assay, from the lowest: compound 2; then compounds 1 and 3 (each within the scatter of the next); then compound 4.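

In this assay, the aromatic carbon para to a large group turns out to allow a wider span of the read-out than the fluoro, methoxy and hydroxy compounds had shown: cyano gives a number 20 percentage points higher from compound 3 to compound 4 (beyond the scatter), a number 29 percentage points higher from compound 1 to compound 4 (beyond the scatter) and a number 45 percentage points higher from compound 2 to compound 4 (beyond the scatter). Among these compounds, the exchange of methoxy for cyano is the only large step at this position, and because each of the steps to compound 4 lies beyond the scatter, compound 4, at 100%, shows the weakest effect of the four at the one concentration tested. Nothing available bears on what lies behind this result.

Going by these compounds, it remains open whether an amine, a carboxylic acid or a trifluoromethyl group on the same aromatic carbon would give a number near that of compound 4 or one near that of compound 2. Also open, on these data alone, is how these compounds would compare across a range of concentrations in this assay, since a single concentration gives the size of the read-out and not a potency.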